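Primary amide to isopropylamide on the shared core

The compounds below may be only part of what the source reports. "The series", "measured", "known", "first", "only" and "open" are said of these compounds alone.

Three analogues of the shared core have been measured in an assay on membranes from HeLa cells for displacement of a labelled ligand from adenosine receptor A3 (Homo sapiens), read by scintillation counting, with a stated time of 180 min, tested at 1 uM; on this read-out higher numbers stand for more inhibition at the one concentration tested (going by the name of the read-out) and lower numbers for less inhibition. Compound 1 `CC1=C(C(=O)NC(C)C)C(c2ccoc2)NC(=O)N1` gives 3%, compound 2 `CC1=C(C(=O)NC(C)C)C(c2cccs2)NC(=O)N1` gives 1%, and compound 3 `CC1=C(C(N)=O)C(c2ccsc2)NC(=O)N1` gives 1%. Going by the values given here, the one single-point step available, a number 2 percentage points lower from compound 1 to compound 2 (within the scatter), concerns the aryl group rather than the amide. Compound 3 sits level with compound 2 and within the scatter of compound 1, so the three numbers lie within the scatter of one another at this concentration.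

Compound 4 `CC1=C(C(=O)NC(C)C)C(c2ccsc2)NC(=O)N1` differs from compound 3 by isopropyl in place of hydrogen on an amide-type nitrogen. Among the compounds with values here, no measured step covers this change, so nothing beyond the scatter is expected; the step from compound 3 is estimated at a number 1 percentage points higher from compound 3 to compound 4 (within the scatter). Compound 4 is therefore expected to give 2%, within -6% to 10%.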

Compound 4, a percentage reported as inhibition, at one concentration (the size of the read-out at that concentration, not a potency): 1%
For compound 4 the middle estimate is 1 percentage points above the measured one, within the range that was stated.
By their numbers in this assay, from the lowest: compounds 2, 3, 4 and 1 (each within the scatter of the next).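

Isopropyl on the amide-type nitrogen gives no change at the digits printed from compound 3 to compound 4 (within the scatter), so with thiophen-3-yl on the core, this assay does not separate the primary amide from the isopropylamide. With isopropylcarbamoyl held constant, the aryl changes read no change at the digits printed from compound 2 to compound 4 (within the scatter) and a number 2 percentage points lower from compound 1 to compound 4 (within the scatter), which extends the same picture to thiophen-3-yl. No supporting data bear on this result.

Open, going by these compounds, is whether a longer chain on the amide nitrogen, or a carboxylic acid in place of the amide, would give a number beyond the scatter of these four compounds.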